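The source may report more compounds than this note shows. Statements on the series, on what has been measured and on what is new or still open speak of the compounds shown alone.

For the measured compounds named here, compound 1 `COc1ccc(-c2cc3ccccc3nc2/C=C/C(=O)c2ccc(OC)cc2OC)cc1` is one of two compounds measured in a functional assay on NCI-H1299 cells (Homo sapiens) for antiproliferative activity, read by XTT assay, with a stated time of 72 h (on this read-out higher numbers stand for weaker inhibition and lower numbers for stronger inhibition), and in this assay compound 1 gives 3770 nM, the lower of the two numbers. Its companion, compound 2 `COc1ccc(-c2cc3ccccc3nc2/C=C/C(=O)c2c(OC)cccc2OC)cc1`, gives 4710 nM in this assay, and the step of a 1.2-fold higher number from compound 1 to compound 2 (0.10 log units; within the scatter) lies within the scatter, so the two cannot be ordered. Compound 3 `COc1ccc(-c2cc3ccccc3nc2/C=C/C(=O)c2ccc[nH]2)cc1` has not been measured; it differs from compound 1 in one place: 1H-pyrrol-2-yl in place of 2,4-dimethoxyphenyl on a carbonyl carbon. Going by the values given here, the single measured step only moves methoxy groups around on a phenyl ring, whereas here the whole ring is exchanged for a smaller one, so no measured step bears on this change, and no direction can be read from the numbers. The number for compound 3 in this assay is therefore expected close to that of compound 1, with a wide range, as an estimated step of a 1.2-fold higher number from compound 1 to compound 3 (0.08 log units; within the scatter), giving an expected 4500 nM between 1500 nM and 14000 nM.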

Compound 3, half-maximal inhibitory concentration: > 10000 nM
Compound 3 ended at the assay's limit; the forecaster's own chance of this, stated with the estimate: 10%; middle value at least 2.2-fold (0.34 log units) away from the limit.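

Compound 3 stands at a limit and not at a number: the limit of > 10000 nM in this assay, at which 1 of the 3 values shown sits.

Even so, putting 1H-pyrrol-2-yl on the carbonyl carbon gives an at least 2.6-fold higher number from compound 1 to compound 3 (0.42 log units; beyond the scatter), and against the other dimethoxyphenyl compound it gives an at least 2.1-fold higher number from compound 2 to compound 3 (0.32 log units; beyond the scatter). Where the earlier pair showed only that moving methoxy groups around the phenyl ring left the two numbers inseparable, this place now proves sensitive to exchanging the ring itself, with inhibition weakened by an amount known only as a minimum.

The exchange alters ring size, removes both methoxy groups and brings in a hydrogen-bond donor all at once, and the compounds shown cannot separate these changes. Going by these compounds, how an unsubstituted phenyl ring or a pyridine ring would behave at this place also remains open.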